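The source may hold more compounds than are shown below. What is called first, only, known or untested is meant among the compounds shown, and "the series" means these compounds.

In a toxicity assay on Huh-7.5 cells (Homo sapiens) for inhibition, read by MTT assay, with a stated time of 96 h (a higher number here means that more compound is tolerated, a lower number that less compound is tolerated), compound 1 `CCC(=O)Nc1cc(C(=O)Nc2ccc(N3CCN(C)CC3)cc2)ccc1OC` gives > 200000 nM, which is a limit of the assay and not a number. Compound 3 `COc1ccc(C(=O)Nc2cc(OC)c(OC)c(OC)c2)cc1NC(=O)C(C)Br` gives 15000 nM. Compound 2 `CN1CCN(Cc2ccc(NC(=O)c3ccc(OCCCCl)c(Cl)c3)cc2C(F)(F)F)CC1` gives 4100 nM, the lowest of the two actual numbers, and its gap to compound 3 lies beyond the scatter.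

Compound 4 `CN1CCN(Cc2ccc(NC(=O)c3ccc(OCCCCl)c(N)c3)cc2C(F)(F)F)CC1` differs from compound 2 in one place: amino in place of chloro on an aromatic carbon. This puts amino in place of chloro on an aromatic carbon, ortho to a 3-chloropropoxy group. Among the measured compounds shown here, no measured pair isolates this change. In this assay, a modest step towards a higher number is expected, since compound 2 at 4100 nM sits lowest and compound 3 stands at 15000 nM. The expected step is a 2.2-fold higher number from compound 2 to compound 4 (0.34 log units; beyond the scatter). For compound 4 the estimated value is 9000 nM, with an expected range of 3500 nM to 25000 nM.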

Compound 4, half-maximal cytotoxic concentration: 12900 nM
Estimate against measurement, compound 4: 1.4-fold (0.16 log units) below; low and high end bracket the measured number.
By their numbers in this assay, from the lowest: compound 2; then compounds 4 and 3 (each within the scatter of the next). At a limit, above all of these: compound 1.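

Amino in place of chloro, ortho to a 3-chloropropoxy group, gives a 3.1-fold higher number from compound 2 to compound 4 (0.50 log units; beyond the scatter) in this assay. Among the compounds shown here, this is the first one-place step, and it shows that the group at this position changes how much compound is tolerated. The step is modest, and compound 4 remains a measured number, short of the limit: the limit of > 200000 nM in this assay, at which 1 of the 4 values shown sits.

From the compounds shown here alone, whether the step follows from gaining amino or from losing chloro stays open. A hydroxyl or fluoro group at this position could separate the two readings.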